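The source may report more compounds than this note shows. Statements on the series, on what has been measured and on what is new or still open speak of the compounds shown alone.

Values measured in a functional assay on HaCaT cells (Homo sapiens) for cytotoxicity, with a stated time of 48 h (a higher number here means a weaker inhibitor, a lower number a stronger inhibitor), follow
- Compound 1 `COc1cc(O)c(C(=O)/C=C/c2ccc(F)cc2)c(OC)c1`: only a limit of the assay (> 20000 nM)
- Compound 2 `COc1cc(OC)c(C(=O)/C=C/c2ccccc2SC)c(OC)c1`: (7700 nM)
- Compound 3 `COc1cc(O)c(C(=O)/C=C/c2ccccc2OC)c(OC)c1`: (10900 nM)

Going by the values given here, compound 2 (7700 nM) lies within the scatter of compound 3 (10900 nM), and these are the only two true numbers in the set. Compound 4 `COc1cc(OC)c(C(=O)/C=C/c2ccc(Cl)cc2)c(OC)c1` has 4-chlorophenyl in place of 2-(methylsulfanyl)phenyl on a double-bonded chain carbon bound to a double-bonded chain carbon. Among the compounds with values here, no measured pair shows this change on its own. In this assay a modest step towards a higher number is expected, since the remaining measured compound, compound 1, reached only a limit (> 20000 nM). The expected change is (a 1.6-fold higher number from compound 2 to compound 4 (0.19 log units; within the scatter)). For compound 4 the estimated value is 12000 nM, with an expected range from 4500 nM to 30000 nM in this assay.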

Compound 4, half-maximal inhibitory concentration: 7600 nM
The estimate for compound 4 lay 1.6-fold (0.20 log units) above the measured number, within the range that was stated.
By their numbers in this assay, from the lowest: compounds 4, 2 and 3 (each within the scatter of the next). At a limit, above all of these: compound 1.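

In this assay, going by these compounds alone, 4-chlorophenyl in place of 2-(methylsulfanyl)phenyl gives a 1.0-fold lower number from compound 2 to compound 4 (0.01 log units; within the scatter) and is the first change at this position that can be read on its own. The sulfur and the hydrogen-bond acceptor of the leaving group can thus go without a shift beyond the scatter. Only compound 1 sits at a limit, so this step joins two true numbers: the limit of > 20000 nM in this assay, at which 1 of the 4 values shown sits.

From the compounds shown here alone, whether an amine or a carboxylic acid on the ring would leave the number unchanged stays open. So does whether the same exchange behaves alike on the core of compound 3.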